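Replacing 2-aminophenyl with (1,3-thiazol-2-yl)oxy in compound 2

The source may hold more compounds than are shown below. What is called first, only, known or untested is meant among the compounds shown, and "the series" means these compounds.

In a functional assay on K562 cells (Homo sapiens) for inhibition, read by fluorescence and resazurin assay, with a stated time of 72 h (on this read-out higher numbers stand for weaker inhibition of growth and lower numbers for stronger inhibition of growth), compound 2 (`Nc1ccccc1-c1ccc(Nc2nc(N[C@H]3CC[C@H](N)CC3)nc3c2ncn3C2CCCC2)cc1`) gives 1070 nM. This lies within the scatter of both compound 1 (`N[C@H]1CC[C@H](Nc2nc(Nc3ccc(-c4ccccc4O)cc3)c3ncn(C4CCCC4)c3n2)CC1`) at 2080 nM and compound 3 (`COc1ccc(-c2ccc(Nc3nc(N[C@H]4CC[C@H](N)CC4)nc4c3ncn4C3CCCC3)cn2)cc1`) at 698 nM. Compound 4 (`N[C@H]1CC[C@H](Nc2nc(Nc3ccc(Oc4nccs4)cc3)c3ncn(C4CCCC4)c3n2)CC1`) departs from compound 2 in one place: (1,3-thiazol-2-yl)oxy in place of 2-aminophenyl on an aromatic carbon. Among the compounds with values here, the only measured step that bears on this place is a 1.9-fold lower number from compound 1 to compound 2 (0.29 log units; within the scatter), where amino takes the place of hydroxy on an aromatic carbon. That step does not replace the whole group, so it is only a loose guide, and the range must stay wide. No change beyond the scatter is expected, and the estimated step is a 1.2-fold lower number from compound 2 to compound 4 (0.08 log units; within the scatter). For compound 4, the estimated value is 900 nM, with an expected range of 250 nM to 3000 nM.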

Compound 4, concentration for 50% growth inhibition: 676 nM
The estimate for compound 4 lay 1.3-fold (0.12 log units) above the measured number; the measured number falls inside the stated range.
By their numbers in this assay, from the lowest: compounds 4, 3, 2 and 1 (each within the scatter of the next, the first and the last beyond it).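

Replacing the whole 2-aminophenyl group with (1,3-thiazol-2-yl)oxy gives a 1.6-fold lower number from compound 2 to compound 4 (0.20 log units; within the scatter) so this position, para to a large group, tolerates a five-membered aromatic ring with no hydrogen-bond donor in place of a six-membered carbon ring. Set against 2-hydroxyphenyl, the same group gives a 3.1-fold lower number from compound 1 to compound 4 (0.49 log units; beyond the scatter) and, unlike the earlier step at this position, that step clears the scatter. No measurement at hand explains either step. The compounds shown do not separate the oxygen link from the thiazole ring. From the compounds shown here alone, how a phenoxy or morpholine group would read at this position remains open.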